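This account rests on a few compounds, and the source may have more. Where it says the series, first, only, none or still open, it means among the compounds named here.

Measured so far in a functional assay on HEK293 cells for positive allosteric modulation of metabotropic glutamate receptor 5 (Homo sapiens), read by calcium flux; a lower number here means a smaller maximal response, a higher number a larger maximal response:
compound 1 `CC(C)(C)C(=O)N1CCCn2nc(COc3ccccc3)cc21` gives 64%
compound 2 `O=C(C1CC1)N1CCCn2nc(COc3ccccc3)cc21` gives 61%
compound 3 `O=C(c1ccccc1F)N1CCCn2nc(COc3ccccc3)cc21` gives 62%

All three share one core and differ only in the group on the carbonyl carbon. Compound 2 stands lowest of the three numbers, but its nearest neighbour, compound 3, lies only a number 1 percentage points higher from compound 2 to compound 3 (within the scatter), and the step of a number 3 percentage points lower from compound 1 to compound 2 (within the scatter) is likewise within the scatter, so the three are not separable in this assay.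

Compound 4 `O=C(c1ccc(Cl)cc1)N1CCCn2nc(COc3ccccc3)cc21` is not yet measured. Relative to compound 2 the change is 4-chlorophenyl in place of cyclopropyl on a carbonyl carbon. The step that bears most directly on it is a number 1 percentage points higher from compound 2 to compound 3 (within the scatter), where an aromatic ring also replaces cyclopropyl on the carbonyl carbon; the steps of a number 2 percentage points lower from compound 1 to compound 3 (within the scatter) and a number 3 percentage points lower from compound 1 to compound 2 (within the scatter) show that tert-butyl, cyclopropyl and 2-fluorophenyl at this position give numbers that cannot be told apart. Within the data shown here, no measured pair speaks to a chlorine on the ring. On this basis no step beyond the scatter is expected in this assay for compound 4, in either direction, so the expected step is a number 1 percentage points higher from compound 2 to compound 4 (within the scatter). Compound 4 is therefore estimated at 62%, with a range from 52% to 72%.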

Compound 4, largest response reached (reported as percent of maximum), in percent of the reference or control that the assay uses: 68%
Compound 4: the middle estimate sits 6 percentage points below what was measured, and the stated range covers the measured number.
By their numbers in this assay, from the lowest: compounds 2, 3, 1 and 4 (each within the scatter of the next).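

In this assay the place on the carbonyl carbon also accepts a chlorine-bearing aromatic ring: 4-chlorophenyl, with 7 heavy atoms against the 3 of cyclopropyl, stays within the scatter of cyclopropyl (a number 7 percentage points higher from compound 2 to compound 4 (within the scatter)), of 2-fluorophenyl (a number 6 percentage points higher from compound 3 to compound 4 (within the scatter)) and of tert-butyl (a number 4 percentage points higher from compound 1 to compound 4 (within the scatter)). Among these compounds, the four groups, two of them aromatic rings and two without one, therefore cannot be told apart by largest response reached, and the chlorine, on which no earlier pair had a bearing, brings no step beyond the scatter. No supporting data are available that would explain the numbers at this position.

Left open is whether an amine, a carboxylic acid or a longer alkyl chain on the carbonyl carbon would give a step beyond the scatter. Going by these compounds, the contribution of the chlorine alone would need a pair with plain phenyl, and since all four compounds share the rest of the core, the effect of any change there on the largest response also stays open.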